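The source may hold more compounds than are shown below. What is called first, only, known or untested is meant among the compounds shown, and "the series" means these compounds.

Compound 1, `CC1CC/C(=N\Nc2ccc(F)cc2)c2ncc(C(=O)O)c(=O)n21`, is the starting point of this account. In a functional assay on the whole organism for inhibition, with Rattus norvegicus as the target (a lower number here means that less compound is needed, a higher number that more compound is needed for the effect), compound 1 gives > 1000 umol/kg, which is a limit of the assay and not a number. Two close relatives were tested as well. Compound 2, `CC1CC/C(=N\Nc2cccc(Cl)c2)c2ncc(C(=O)O)c(=O)n21`, carries 3-chlorophenyl in place of 4-fluorophenyl on an amine nitrogen; in this assay compound 2 gives > 100 umol/kg, again a limit. Compound 3, `CC1CC/C(=N\Nc2ccccc2O)c2ncc(C(=O)O)c(=O)n21`, carries 2-hydroxyphenyl on that amine nitrogen; in this assay compound 3 gives > 100 umol/kg, also a limit. None of the steps among these three can be read: a step that the two limits leave unreadable from compound 1 to compound 2, a step that the two limits leave unreadable from compound 1 to compound 3 and a step that the two limits leave unreadable from compound 2 to compound 3. Where compound 1 stands is therefore known only as a limit, and the limit of > 100 umol/kg in this assay, at which 2 of the 3 values shown sit, together with the limit of > 1000 umol/kg in this assay, at which 1 of the 3 values shown sits, is all the evidence the series offers.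

Compound 4, `CCCCc1ccc(N/N=C2\CCC(C)n3c2ncc(C(=O)O)c3=O)cc1`, differs from compound 1 by butyl in place of fluoro on an aromatic carbon. For the measured compounds named here, no measured step bears on a change of this kind, since every step in the set is unreadable, so no direction can be drawn from the data and no step beyond the scatter is expected. Compound 4 is expected to show a number no higher from compound 1 to compound 4 (the limit leaves the size open). Compound 4 is estimated to give 1000 umol/kg in this assay, within 100 umol/kg to 10000 umol/kg, and a limit rather than a number is the likelier outcome.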

Compound 4, dose for 50% inhibition: 100 umol/kg
The estimate for compound 4 lay 10-fold (1.00 log units) above the measured number; the range from low to high includes it.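

For the compounds shown here, with the change made on an aromatic carbon of a six-membered aromatic ring of carbon only, para to a large group, butyl in place of fluoro gives an at least 10-fold lower number from compound 1 to compound 4 (1.00 log units; beyond the scatter) in this assay, the first step whose direction can be read. Compound 4 is also the only one of the four compounds to give a number rather than a limit, so this position is shown to respond to the exchange of substituent, although the full size of the step stays open and the printed size is only its least extent. The values shown hold no measured property of butyl or fluoro that would account for the step.

Going by these compounds alone, what remains open is whether a shorter chain such as ethyl, a longer chain such as hexyl or a branched group such as tert-butyl on the same aromatic carbon would give a number, and how that number would stand against the one for compound 4. Equally open, on these data alone, is whether butyl would have any such effect on the ring carbon that carries chloro in compound 2, or whether an ether such as methoxy would serve at the position of the butyl.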